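Changing the Side Chain of a Strong Inhibitor

The source may hold more compounds than are shown below. What is called first, only, known or untested is meant among the compounds shown, and "the series" means these compounds.

Values in a functional assay on RS4-11 cells (Homo sapiens) for inhibition, read by CCK-8 assay, with a stated time of 72 h (a lower number here means a stronger inhibitor, a higher number a weaker inhibitor), are:
- compound 1 `CC1(C)CCC(CN2CCN(c3ccc(C(=O)NS(=O)(=O)c4ccc(NCC5CCOCC5)c([N+](=O)[O-])c4)c(Oc4cnc5[nH]ccc5c4)c3)CC2)=C(c2ccc(Cl)cc2C(F)(F)F)C1` gives 74 nM
- compound 2 `CC1(C)CCC(CN2CCN(c3ccc(C(=O)NS(=O)(=O)c4ccc(NCC5CCOCC5)c([N+](=O)[O-])c4)c(Oc4cnc5[nH]ccc5c4)c3)CC2)=C(c2ccc(C(F)(F)F)c(Cl)c2)C1` gives 81 nM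
- compound 3 `CN(C)CCCNc1ccc(S(=O)(=O)NC(=O)c2ccc(N3CCN(CC4=C(c5ccc(C(F)(F)F)cc5)CC(C)(C)CC4)CC3)cc2Oc2cnc3[nH]ccc3c2)cc1[N+](=O)[O-]` gives 3.9 nM

Compound 3 gives 3.9 nM as the lowest number of the three, well beyond the scatter from the other two. Compound 4 `CC(C)C(=O)N1CCC(CNc2ccc(S(=O)(=O)NC(=O)c3ccc(N4CCN(CC5=C(c6ccc(C(F)(F)F)cc6)CC(C)(C)CC5)CC4)cc3Oc3cnc4[nH]ccc4c3)cc2[N+](=O)[O-])CC1` changes its side chain (1-(isopropylcarbonyl)piperidin-4-yl in place of 2-(dimethylamino)ethyl on a saturated chain carbon bound to a nitrogen on an aromatic ring) and keeps the aryl group of compound 3. For the measured compounds named here, the only measured step (a 1.1-fold higher number from compound 1 to compound 2 (0.04 log units; within the scatter)) swaps that aryl group, not the chain, so it says little here. Compound 1 and compound 2 also carry a ring in the chain and give higher numbers, but their aryl groups differ too, so this evidence is weak. A weaker result is still expected, with a 5.1-fold higher number from compound 3 to compound 4 (0.71 log units; beyond the scatter) as the estimated step. Compound 4 is estimated at 20 nM within a wide expected range (5 nM to 80 nM).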

Compound 4, half-maximal inhibitory concentration: 5.3 nM
The estimate for compound 4 lay 3.8-fold (0.58 log units) above the measured number; low and high end bracket the measured number.
By their numbers in this assay, from the lowest: compounds 3 and 4 (each within the scatter of the next); then compounds 1 and 2 (each within the scatter of the next).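

In this assay the step from the open chain to the ring-bearing chain (a 1.4-fold higher number from compound 3 to compound 4 (0.13 log units; within the scatter)) shows that this position accepts 1-(isopropylcarbonyl)piperidin-4-yl in place of 2-(dimethylamino)ethyl without a change beyond the scatter. The earlier compounds shown here with a ring in this chain also differ in their aryl group, so they could not show this. Nothing measured here explains the result. On these data alone, how a free piperidin-4-yl, a carboxylic acid or a longer chain would read at this place stays open.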